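The source may report more compounds than this note shows. Statements on the series, on what has been measured and on what is new or still open speak of the compounds shown alone.

Compound 2 `O=C(CC(CC(=O)NC1Cc2ccccc2C1)c1ccc(Cl)cc1)NCCN1CCCC1` carries a pyrrolidin-1-yl group on its side chain. In a functional assay on L02 cells (Homo sapiens) for inhibition (a higher number here means a weaker inhibitor, a lower number a stronger inhibitor), compound 2 gives 89400 nM. Compound 1 `CCN(CC)CCNC(=O)CC(CC(=O)NC1Cc2ccccc2C1)c1ccc(Cl)cc1` differs from it in one place: diethylamino in place of pyrrolidin-1-yl on a saturated chain carbon, two bonds along the chain from an amide-type nitrogen. In this assay compound 1 gives 76700 nM, so this swap of one amine for the other amounts to a 1.2-fold lower number from compound 2 to compound 1 (0.07 log units; within the scatter).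

Compound 3 `CN(C(=O)CC(CC(=O)NCCN1CCCC1)c1ccccc1)C1Cc2ccccc2C1` has a core that differs from that of compound 2 in more than one place, and the difference between the two cores is not broken down here. In this assay compound 3 reaches only > 100000 nM, which is a limit of the assay rather than a number; it sits at the limit of > 100000 nM in this assay, at which 1 of the 3 values shown sits.

Compound 4 `CCN(CC)CCNC(=O)CC(CC(=O)N(C)C1Cc2ccccc2C1)c1ccccc1` is not yet measured. It stands to compound 3 as compound 1 stands to compound 2: diethylamino in place of pyrrolidin-1-yl on a saturated chain carbon, two bonds along the chain from an amide-type nitrogen. The place is the same in both pairs, so this is the same change. Since that change gave a 1.2-fold lower number from compound 2 to compound 1 (0.07 log units; within the scatter), the expected step that the limit leaves unreadable from compound 3 to compound 4 is likewise small. Compound 4 is therefore expected to give about 120000 nM, most likely again only a limit, between 60000 nM and 300000 nM.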

Compound 4, half-maximal inhibitory concentration: > 100000 nM
Compound 4 was reported as a limit; the forecaster's own chance of this, stated with the estimate: 70%; the middle value does not contradict the limit.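

Compound 3 and compound 4 are both reported in this assay only as limits, so no step between them can be read: the limit of > 100000 nM in this assay, at which 2 of the 4 values shown sit.

The compounds shown leave open whether diethylamino in place of pyrrolidin-1-yl makes any difference on the core of compound 3, and how far beyond the limit either compound lies.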